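Stretching the Chain on the Ring Nitrogen of Compound 3

A few compounds are considered here, and "the series" means these few. Any claim that something is new, unique, unknown or untested is made for them only; others in the source may bear on it.

Compound 1 `CC(C)CCn1cnc2c(Nc3ccccc3)nc(N[C@H]3CC[C@H](N)CC3)nc21`: 21700 nM
Compound 2 `CCCCn1cnc2c(Nc3ccc(Cl)cc3)nc(N[C@H]3CC[C@H](N)CC3)nc21`: 10800 nM
Compound 3 `CCCCn1cnc2c(Nc3cccc(Cl)c3)nc(N[C@H]3CC[C@H](N)CC3)nc21`: 7200 nM

Of the compounds shown here, three have been measured in a functional assay on HCC827 cells (Homo sapiens) for inhibition, read by fluorescence, with a stated time of 72 h; on this read-out higher numbers stand for weaker inhibition of growth and lower numbers for stronger inhibition of growth. Compound 3 gives the lowest of the three numbers. Compound 2 lies nearest to it, and the step of a 1.5-fold lower number from compound 2 to compound 3 (0.18 log units; within the scatter) is within the scatter. Compound 1, which differs from compound 3 in two places, gives a clearly higher number. Compound 4 `CC(C)=CCC/C(C)=C/Cn1cnc2c(Nc3cccc(Cl)c3)nc(N[C@H]3CC[C@H](N)CC3)nc21` differs from compound 3 by 2,6-dimethylhepta-1,5-dien-1-yl in place of propyl on a saturated chain carbon bound to an aromatic nitrogen. Within the data shown here, none of the measured steps changes this chain on its own, so no measured step bears directly on the change. With nothing to lean on, the expectation for compound 4 is no step beyond the scatter, a 1.0-fold lower number from compound 3 to compound 4 (0.01 log units; within the scatter), held with a wide range. Compound 4 is therefore estimated at 7000 nM, between 2300 nM and 21000 nM.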

Compound 4, concentration for 50% growth inhibition: 18200 nM
The estimate for compound 4 lay 2.6-fold (0.41 log units) below the measured number; the range from low to high includes it.
By their numbers in this assay, from the lowest: compounds 3, 2, 4 and 1 (each within the scatter of the next, the first and the last beyond it).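

In this assay, the position on the ring nitrogen proves sensitive to the chain it carries: 2,6-dimethylhepta-1,5-dien-1-yl in place of propyl gives a 2.5-fold higher number from compound 3 to compound 4 (0.40 log units; beyond the scatter), a modest weakening of growth inhibition. The earlier compounds shown here offered no step at this position on its own. No available measurement gives a reason for this step.

The compounds shown do not separate the effect of chain length from that of the double bonds. As far as these compounds go, how a saturated octyl chain, a methyl group or a chain ending in an amine would fare remains open.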